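Swapping Naphthyl for Dimethoxyphenyl on the Benzylidene Arm

A few compounds are considered here, and "the series" means these few. Any claim that something is new, unique, unknown or untested is made for them only; others in the source may bear on it.

Measured in a functional assay on HT-29 cells (Homo sapiens) for cytotoxicity, read by MTT assay, with a stated time of 72 h; a higher number here means a weaker inhibitor, a lower number a stronger inhibitor:
compound 1 `O=C1N/C(=N/c2csc(-c3ccc(Cl)cc3)c2)S/C1=C\c1ccccc1` gives 10500 nM
compound 2 `O=C1N/C(=N/c2csc(-c3ccc(Cl)cc3)c2)S/C1=C\c1ccc(Br)cc1` gives 2000 nM
compound 3 `O=C1N/C(=N/c2csc(-c3ccc(Cl)cc3)c2)S/C1=C\c1ccc2ccccc2c1` gives 3700 nM

Compound 3 holds the second highest of the three numbers; its nearest neighbour is compound 2, the two lying within the scatter of each other, while compound 1 sits further off, as a 2.8-fold lower number from compound 1 to compound 3 (0.45 log units; beyond the scatter) shows. Compound 4 `COc1ccc(/C=C2\S/C(=N\c3csc(-c4ccc(Cl)cc4)c3)NC2=O)cc1OC` differs from compound 3 by 3,4-dimethoxyphenyl in place of naphthalen-2-yl on a double-bonded chain carbon bound to a double-bonded ring carbon. Among the compounds with values here, no measured step exchanges the naphthyl for a substituted phenyl of this kind; the steps that bear on the arm are a 2.8-fold lower number from compound 1 to compound 3 (0.45 log units; beyond the scatter) and a 1.9-fold higher number from compound 2 to compound 3 (0.27 log units; within the scatter), both modest or within scatter, and a 5.3-fold lower number from compound 1 to compound 2 (0.72 log units; beyond the scatter), where a substituent on the phenyl lowered the number. Compound 4 is therefore expected to land close to compound 3, with a 1.2-fold higher number from compound 3 to compound 4 (0.09 log units; within the scatter). Compound 4 is estimated at 4500 nM, within a range of 1500 nM to 14000 nM.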

Compound 4, half-maximal inhibitory concentration: 10900 nM
Estimate against measurement, compound 4: 2.4-fold (0.38 log units) below, within the range that was stated.
By their numbers in this assay, from the lowest: compounds 2 and 3 (each within the scatter of the next); then compounds 1 and 4 (each within the scatter of the next).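

In this assay the 3,4-dimethoxyphenyl group does not share the lower numbers of the naphthalen-2-yl and 4-bromophenyl groups at this position: a 2.9-fold higher number from compound 3 to compound 4 (0.47 log units; beyond the scatter) and a 5.5-fold higher number from compound 2 to compound 4 (0.74 log units; beyond the scatter) both lie beyond the scatter, whereas a 1.0-fold higher number from compound 1 to compound 4 (0.02 log units; within the scatter) lies within it. Substituting the phenyl therefore does not by itself lower the number, since the bromo group does so and the two methoxy groups do not. Nothing available accounts for this difference. The compounds shown leave open whether a single methoxy group or a dimethylamino group on the phenyl would follow the bromo group or the methoxy pair.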